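The source may hold more compounds than are shown below. What is called first, only, known or untested is meant among the compounds shown, and "the series" means these compounds.

Measured so far in a functional assay on BXPC-3 cells (Homo sapiens) for inhibition, read by MTT assay, with a stated time of 7 days; on this read-out lower numbers stand for stronger inhibition and higher numbers for weaker inhibition

compound 1 `CCN(CC)S(=O)(=O)c1ccc(S(=O)(=O)N2CCC[C@@H](C(=O)N3CCC(O)CC3)C2)cc1` gives 4710 nM
compound 2 `CCC(CC)S(=O)(=O)c1ccc(S(=O)(=O)N2CCC[C@@H](C(=O)N3CCC(F)(F)CC3)C2)cc1` gives 40 nM
compound 3 `CCN(CC)S(=O)(=O)c1ccc(S(=O)(=O)N2CCC[C@@H](C(=O)NC3COC3)C2)cc1` gives 13800 nM

Of these three numbers, compound 2 has the lowest, and its gaps to compound 1 and compound 3 both lie beyond the scatter. The next compound, compound 4 `CCN(CC)C(=O)c1ccc(S(=O)(=O)N2CCC[C@@H](C(=O)N3CCC(F)(F)CC3)C2)cc1`, keeps the rest of compound 2 and carries diethylcarbamoyl in place of (pentan-3-yl)sulfonyl on an aromatic carbon, para to a large group (diethylcarbamoyl in place of (pentan-3-yl)sulfonyl on an aromatic carbon).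

Within the data shown here, the only measured single-place step is a 2.9-fold higher number from compound 1 to compound 3 (0.47 log units; beyond the scatter), where (oxetan-3-yl)amino replaces 4-hydroxypiperidin-1-yl on a carbonyl carbon. That step is at a different place, so it sets no direct size for this change. Compound 2 differs from compound 1 in more than one place, so their gap cannot be assigned to either place. It does show how far numbers can spread in this small set, with compound 2 at 40 nM and compound 1 at 4710 nM in the same read-out.

With compound 2 at the low end of the set, a move to a higher number is the more likely outcome. The expected change is a 5.0-fold higher number from compound 2 to compound 4 (0.70 log units; beyond the scatter) in this assay, and this estimate is loose. For compound 4 the value is expected to lie near 200 nM (estimated range 40 nM to 1200 nM).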

Compound 4, half-maximal inhibitory concentration: 240 nM
Estimate against measurement, compound 4: 1.2-fold (0.08 log units) below; the range from low to high includes it.
By their numbers in this assay, from the lowest: compound 2; then compound 4; then compound 1; then compound 3.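

In this assay, among these compounds, this is the first measured step at this aromatic carbon, para to a large group, and it gives a 6.0-fold higher number from compound 2 to compound 4 (0.78 log units; beyond the scatter) with the rest of compound 2 unchanged. The position therefore responds beyond the scatter to a swap of diethylcarbamoyl for (pentan-3-yl)sulfonyl, even though both groups have five carbons, no ring and no net charge, and the entering group has a nitrogen and one oxygen where the leaving group has a sulfur and two oxygens. Nothing measured here explains the size of this step.

Because this single step swaps the whole group, it cannot show whether the change in the number follows from the linking atoms or from the arrangement of the carbons attached to them. The compounds shown also leave open how this carbon would read with a nitrile, a carboxylic acid or a shorter ethylsulfonyl chain, and whether the same swap would give a step of similar size with the 4-hydroxypiperidin-1-yl or (oxetan-3-yl)amino groups on the carbonyl carbon.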